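Ethyl to cyclobutyl: the step to compound 4

The source may report more compounds than this note shows. Statements on the series, on what has been measured and on what is new or still open speak of the compounds shown alone.

Compound 1 `CCNC1=NS(=O)(=O)c2cccc(Cl)c2N1` gives 90400 nM
Compound 2 `O=S1(=O)N=C(NC2CCC2)Nc2c(Cl)cccc21` gives 126000 nM
Compound 3 `CCNC1=NS(=O)(=O)c2ccc(Cl)cc2N1` gives 54800 nM

In a functional assay on aorta (Rattus norvegicus) for inhibition (on this read-out lower numbers stand for an effect already at smaller amounts and higher numbers for an effect only at larger amounts of compound), compound 3 stands at 54800 nM and lies within the scatter of compound 1 at 90400 nM while compound 2 at 126000 nM lies beyond the scatter of compound 3 on the higher side. Compound 4 `O=S1(=O)N=C(NC2CCC2)Nc2cc(Cl)ccc21` has not yet been measured. Relative to compound 3 it carries cyclobutyl in place of ethyl on an amine nitrogen and nothing else changes. One measured step makes the same exchange on a closely related core. Going by that step (a 1.4-fold higher number from compound 1 to compound 2 (0.14 log units; within the scatter)) no step beyond the scatter is expected for compound 4 in this assay and at most a slight drift toward a higher number. Going by the values given here, only one such step exists, so the range is kept wide. The estimated change is a 1.4-fold higher number from compound 3 to compound 4 (0.13 log units; within the scatter) on this reading. Compound 4 is expected at 74000 nM with 38000 nM to 145000 nM as its estimated range.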

Compound 4, half-maximal effective concentration: > 300000 nM
Compound 4: no number, only a limit; the forecaster's own chance of this, stated with the estimate: 5%; at least 4.0-fold (0.60 log units) between middle value and limit.
By their numbers in this assay, from the lowest: compounds 3, 1 and 2 (each within the scatter of the next, the first and the last beyond it). At a limit, above all of these: compound 4.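

In this assay compound 4 gives > 300000 nM, which is a limit of the assay and not a number. Going by these compounds alone, the step reads an at least 5.4-fold higher number from compound 3 to compound 4 (0.73 log units; beyond the scatter), so the exchange of ethyl for cyclobutyl on an amine nitrogen does not behave alike on the two cores: the same change on two cores in this assay, a 1.4-fold higher number (0.14 log units; within the scatter) from compound 1 to compound 2 and an at least 5.4-fold higher number (0.73 log units; beyond the scatter) from compound 3 to compound 4, at least 3.9-fold (0.59 log units) apart, beyond the scatter of two such steps On the core of compound 1 the same exchange had stayed within the scatter, so the earlier compounds gave no sign that its outcome depends on the core.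

The compounds shown leave open how far beyond its limit compound 4 lies, and so how wide the gap between the two steps really is. They also leave open whether a propyl or cyclopropyl group on that nitrogen would track ethyl or cyclobutyl on either core.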